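This account rests on a few compounds, and the source may have more. Where it says the series, first, only, none or still open, it means among the compounds named here.

Compound 2 `CCCCc1oc2ccccc2c1C(=O)c1ccc(OCC(=O)N2CCOCC2)cc1` gives > 50000 nM in a functional assay on MDA-MB-231 cells (Homo sapiens) for antiproliferative activity, read by MTT assay, with a stated time of 24 h (on this read-out lower numbers stand for stronger inhibition and higher numbers for weaker inhibition), and this is a limit of the assay, not a number. It is the limit of > 50000 nM in this assay, at which 1 of the 3 values shown sits. Compound 1 `CCCCNC(=O)COc1ccc(C(=O)c2c(CCCC)oc3ccccc23)cc1` gives 34500 nM, and compound 3 `CCCCc1oc2ccccc2c1C(=O)c1ccc(OCC(=O)N2CCN(C(=O)OC(C)(C)C)CC2)cc1` gives 36900 nM.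

Compound 4 `CCCCNC(=O)CCCOc1ccc(C(=O)c2c(CCCC)oc3ccccc23)cc1` has not yet been measured. Its difference from compound 2 is 2-(butylcarbamoyl)ethyl in place of (morpholin-4-yl)carbonyl on a saturated chain carbon bound to an oxygen on an aromatic ring. Put another way, ((morpholin-4-yl)carbonyl)methyl gives way to 3-(butylcarbamoyl)propyl.

For the measured compounds named here, one measured step bears on this change: morpholin-4-yl in place of butylamino on a carbonyl carbon, with an at least 1.4-fold higher number from compound 1 to compound 2 (0.16 log units; that floor lies within the scatter). Going by the values given here, compound 4 reverses that exchange in part, since it carries a butylcarbamoyl group, but no measured step covers its longer chain. Compound 2 offers only a limit as a starting point, so a modest move towards lower numbers in this assay is expected, possibly none beyond the scatter. The expected change is an at least 1.5-fold lower number from compound 2 to compound 4 (0.19 log units; that floor lies within the scatter). For compound 4 the estimated value is 32000 nM, with an expected range from 15000 nM to 60000 nM.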

Compound 4, half-maximal inhibitory concentration: 38100 nM
Compound 4: the middle estimate sits 1.2-fold (0.08 log units) below what was measured; low and high end bracket the measured number.
By their numbers in this assay, from the lowest: compounds 1, 3 and 4 (each within the scatter of the next). At a limit, above all of these: compound 2.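

In this assay, the change from butylcarbamoyl to 2-(butylcarbamoyl)ethyl on a saturated chain carbon bound to an oxygen on an aromatic ring reads as a 1.1-fold higher number from compound 1 to compound 4 (0.04 log units; within the scatter), so the two chains cannot be told apart at this place. The exchange of (morpholin-4-yl)carbonyl for 2-(butylcarbamoyl)ethyl at the same place reads as an at least 1.3-fold lower number from compound 2 to compound 4 (0.11 log units; that floor lies within the scatter), and this figure is only a floor, with no true size attached to it. Compound 2 holds a limit of the assay and not a number: the limit of > 50000 nM in this assay, at which 1 of the 4 values shown sits.

The compounds shown leave open whether a longer chain at this place, or a carboxylic acid or a primary amine in place of the butylcarbamoyl end, would shift the number in this assay beyond the scatter. As far as these compounds go, how far compound 2 truly lies from compound 4 also remains open, and so does the effect of a morpholine amide on the longer chain, which would separate the chain length from the amide group.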